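The source may report more compounds than this note shows. Statements on the series, on what has been measured and on what is new or still open speak of the compounds shown alone.

Compound 1 `CCN(CC)c1cc2[nH]c(-c3ccccc3)nc2cc1NC(=O)c1ccc(C)cc1` shows > 200 ug/mL in an ADME assay on Vero cells (Chlorocebus sabaeus) for cytotoxicity, with a stated time of 3 days (a lower number here means a stronger inhibitor, a higher number a weaker inhibitor), a limit of the assay rather than a number.
Compound 2 `CCOC(=O)Nc1cc(NC(=O)c2ccccc2OC)c2[nH]c(-c3ccc(Br)cc3)nc2c1` shows > 200 ug/mL in this assay, likewise a limit.

Compound 2 therefore stands at the limit of > 200 ug/mL in this assay, at which 2 of the 2 values shown sit, and no number is known for it. Compound 3 `CCOC(=O)Nc1cc(NC(=O)c2ccccc2)c2[nH]c(-c3ccc(Br)cc3)nc2c1` differs from compound 2 by hydrogen in place of methoxy on an aromatic carbon. Going by the values given here, no step between measured compounds is available, so the expected step that the limit leaves unreadable from compound 2 to compound 3 in this assay is none beyond the scatter. Compound 3 is estimated at 250 ug/mL, between 100 ug/mL and 600 ug/mL, most likely reported once more only as a limit.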

Compound 3, half-maximal inhibitory concentration: > 200 ug/mL
Compound 3: a limit, no number (the forecaster's own chance of this, stated with the estimate: 80%); the middle value lies beyond the limit too.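

Going by these compounds alone, compound 2 and compound 3 both stand only as limits in this assay, so no step between them can be read: the limit of > 200 ug/mL in this assay, at which 3 of the 3 values shown sit. The compounds shown leave open whether methoxy or hydrogen on this aromatic carbon makes any difference in this assay once a number can be measured.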